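This account rests on a few compounds, and the source may have more. Where it says the series, first, only, none or still open, it means among the compounds named here.

Measured compounds in a functional assay on MCF7 cells (Homo sapiens) for antiproliferative activity, read by MTT assay, with a stated time of 48 h; on this read-out higher numbers stand for weaker inhibition of growth and lower numbers for stronger inhibition of growth:
- compound 1 `CCOc1cc(NC(=O)CCCCCCC(=O)Nc2ccccc2N)cc2c1OCC([N+](=O)[O-])=C2`: 13500 nM
- compound 2 `CCOc1cc(NC(=O)CCCCCCC(=O)Nc2cc(-c3ccc(C)s3)ccc2N)cc2c1OCC([N+](=O)[O-])=C2`: 5330 nM
- compound 3 `CCOc1cc(NC(=O)CCCCCC(=O)Nc2cc(-c3ccc(C)s3)ccc2N)cc2c1OCC([N+](=O)[O-])=C2`: the reading for compound 3 is a limit of this assay, > 20000 nM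

In this assay the change hydrogen in place of 5-methylthiophen-2-yl on an aromatic carbon gives a 2.5-fold higher number from compound 2 to compound 1 (0.40 log units; beyond the scatter). Compound 3 and compound 2 share most of their structure, but the difference between the two cores is not broken down here. Compound 4 `CCOc1cc(NC(=O)CCCCCC(=O)Nc2ccccc2N)cc2c1OCC([N+](=O)[O-])=C2` is still to be measured in this assay; it carries the same change, (hydrogen in place of 5-methylthiophen-2-yl on an aromatic carbon), made on compound 3. The starting point is weaker here, because compound 3 sits at the limit of > 20000 nM in this assay, at which 1 of the 3 values shown sits. Taken beside the measured step, compound 4 is expected to move by about a step that the limit leaves unreadable from compound 3 to compound 4, so the number is expected to stay past the limit and most likely no figure is reported. The estimate for compound 4 in this assay is 50000 nM, within 20000 nM to 200000 nM.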

Compound 4, concentration for 50% growth inhibition: 19500 nM
Beside the measured number, compound 4's estimate is 2.6-fold (0.41 log units) above it; measured number below the stated range.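

In this assay, hydrogen in place of 5-methylthiophen-2-yl on the core of compound 3 gives an at least 1.0-fold lower number from compound 3 to compound 4 (0.01 log units; that floor lies within the scatter), which is only a floor, so its size cannot be set against the step on the other core: the same change on two cores in this assay, a 2.5-fold higher number (0.40 log units; beyond the scatter) from compound 2 to compound 1 and an at least 1.0-fold lower number (0.01 log units; that floor lies within the scatter) from compound 3 to compound 4; the limit leaves it open whether they differ
For compound 3, > 20000 nM is a limit of the assay and not a number.
The pair therefore neither shows that the change carries from one core to the other nor shows that it fails to, while (2-aminophenyl)carbamoyl in place of ((2-aminophenyl)carbamoyl)methyl gives a 1.4-fold higher number from compound 1 to compound 4 (0.16 log units; within the scatter), so the two chains are not told apart among the compounds without the thiophene.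

Still open, on these data alone, is whether a phenyl group or an amine in place of 5-methylthiophen-2-yl would give a step of similar size. Also open, as far as these compounds go, is how a longer chain would read on either form of the compound.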